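A few compounds are considered here, and "the series" means these few. Any claim that something is new, unique, unknown or untested is made for them only; others in the source may bear on it.

Compound 1, `CCCCCCCCOc1nc(N)nc2c1ncn2/C=C1/CC1(CO)CO`, gives in an ADME assay on CCRF-HSB-2 cells (Homo sapiens) for cytotoxicity, with a stated time of 7 days; a higher number here means that more compound is tolerated, a lower number that less compound is tolerated > 20000 nM, a limit of the assay.
Compound 2, `Nc1nc(NC2CC2)c2ncn(/C=C3/CC3(CO)CO)c2n1`, gives in this assay > 20000 nM, also a limit.
Compound 3, `Nc1nc(NCc2ccccc2)c2ncn(/C=C3/CC3(CO)CO)c2n1`, gives in this assay > 20000 nM, again a limit.

Among the measured compounds shown here, compound 3 therefore stands where every value so far sits: the limit of > 20000 nM in this assay, at which 3 of the 3 values shown sit. Compound 4, `Nc1nc(N2CCCC2)c2ncn(/C=C3/CC3(CO)CO)c2n1`, differs from it by pyrrolidin-1-yl in place of benzylamino on an aromatic carbon. The measured steps all run between limits: a step that the two limits leave unreadable from compound 1 to compound 2, a step that the two limits leave unreadable from compound 1 to compound 3 and a step that the two limits leave unreadable from compound 2 to compound 3. None of them has a readable size, so nothing in this assay points in either direction beyond the scatter, and the step expected is a step that the limit leaves unreadable from compound 3 to compound 4. Compound 4 is estimated at 30000 nM, between 15000 nM and 100000 nM, with the expectation that the assay again reports only a limit.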

Compound 4, half-maximal cytotoxic concentration: > 20000 nM
Compound 4 ended at the assay's limit (the forecaster's own chance of this, stated with the estimate: 85%); the middle value is on the limit's open side.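

Compound 4 also gives only a limit, like compound 1, compound 2 and compound 3, so no step among these four can be read: the limit of > 20000 nM in this assay, at which 4 of the 4 values shown sit. In this assay the compounds shown leave open what concentration of any of them would prove cytotoxic.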